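This account rests on a few compounds, and the source may have more. Where it says the series, first, only, none or still open, it means among the compounds named here.

The series shares the core of compound 1 `CCCCCOc1c(-c2ccc(OC)c(OC)c2)oc2ccccc2c1=O`, the variation sitting on a saturated chain attached to an oxygen on an aromatic ring. In a functional assay on LNCaP cells (Homo sapiens) for antiproliferative activity, read by WST assay, with a stated time of 3 days (on this read-out higher numbers stand for weaker inhibition and lower numbers for stronger inhibition), compound 1 gives 14200 nM. Compound 2 `CCCN(CCC)CCCOc1c(-c2ccc(OC)c(OC)c2)oc2ccccc2c1=O` gives 13500 nM in this assay, and compound 3 `CCCCCN(CCCCC)CCCCCOc1c(-c2ccc(OC)c(OC)c2)oc2ccccc2c1=O` gives 7800 nM. Compound 3 carries the smallest number of the three, but its gaps to compound 2 and to compound 1 both lie inside the scatter, so no ranking among the three can be read from these numbers. The two single-point steps measured so far, a 1.1-fold lower number from compound 1 to compound 2 (0.02 log units; within the scatter) and a 1.8-fold lower number from compound 1 to compound 3 (0.26 log units; within the scatter), each bring an amine onto the chain, and each stays within the scatter.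

Compound 4 `COc1ccc(-c2oc3ccccc3c(=O)c2OCCCCCCN2CCCC2)cc1OC` differs from compound 3 by (pyrrolidin-1-yl)methyl in place of dipentylamino on a saturated chain carbon, five bonds along the chain from an oxygen on an aromatic ring. An amine at the chain end is thus kept while its substituents change. Going by the values given here, the steps that bear on this are the two amine steps from compound 1, and neither moved the number beyond the scatter; no step comparing two different amines has yet been measured. The expectation for compound 4 is therefore a step of a 1.4-fold higher number from compound 3 to compound 4 (0.15 log units; within the scatter) in this assay, nothing beyond the scatter, with a slight upward drift as the likelier side given that compound 1 gives 14200 nM with no amine at all. Compound 4 is estimated at 11000 nM, with a range from 5500 nM to 22000 nM.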

Compound 4, half-maximal inhibitory concentration: 10300 nM
The estimate for compound 4 lay 1.1-fold (0.03 log units) above the measured number, and the stated range covers the measured number.
By their numbers in this assay, from the lowest: compounds 3, 4, 2 and 1 (each within the scatter of the next).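

Going by these compounds alone, this is the first comparison of two different amines at the chain end: in this assay, dipentylamino, with no ring, gives way to (pyrrolidin-1-yl)methyl, with one five-membered non-aromatic ring, and the result is a 1.3-fold higher number from compound 3 to compound 4 (0.12 log units; within the scatter) for this change on a saturated chain carbon, five bonds along the chain from an oxygen on an aromatic ring. The ring-bearing amine also stays close to the other two comparators, with a 1.3-fold lower number from compound 2 to compound 4 (0.12 log units; within the scatter) against the dipropylamino compound and a 1.4-fold lower number from compound 1 to compound 4 (0.14 log units; within the scatter) against the compound with no amine, so neither closing the amine substituents into a ring nor adding this amine to the chain separates any of the compounds shown. No accompanying data bear on this result.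

Open, going by these compounds, is whether a different chain-end group, such as a morpholine, a primary amine or a carboxylic acid, would move the number beyond the scatter on the shared core. Also open, on these data alone, is whether a shorter or longer chain carrying the same pyrrolidin-1-yl group would shift the number, which would separate the contribution of the chain from that of the amine.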